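Bromo to iodo on the phenyl ester of coumarin-type cores

The source may hold more compounds than are shown below. What is called first, only, known or untested is meant among the compounds shown, and "the series" means these compounds.

Compound 1 `O=C(Oc1cccc(Br)c1)c1cc2cc([N+](=O)[O-])ccc2oc1=O` and compound 3 `CC(=O)NCc1ccc2oc(=O)c(C(=O)Oc3cccc(Br)c3)cc2c1` differ only in their cores: the core of compound 3 carries acetamidomethyl in place of nitro on an aromatic carbon. In a functional assay on HT-1080 cells (Homo sapiens), read by transwell migration, with a stated time of 24 h, tested at 1 uM (on this read-out higher numbers stand for a weaker effect at the one concentration tested and lower numbers for a stronger effect), compound 1 gives 35.2%, and compound 3 gives 36.9%; the change between them reads a number 1.7 percentage points higher from compound 1 to compound 3 (within the scatter). Compound 2 `O=C(Oc1cccc(I)c1)c1cc2cc([N+](=O)[O-])ccc2oc1=O` is compound 1 with the halogen exchanged, namely (iodo in place of bromo on an aromatic carbon). In this assay compound 2 gives 63.6%, so the exchange made a number 28.4 percentage points higher from compound 1 to compound 2 (beyond the scatter). Compound 4 `CC(=O)NCc1ccc2oc(=O)c(C(=O)Oc3cccc(I)c3)cc2c1`, not yet measured, carries the same change on the core of compound 3: iodo in place of bromo on an aromatic carbon. Going by the values given here, with two cores whose parent values sit within the scatter of each other, the step on compound 3 is expected to resemble the one measured on compound 1, that is a number 21.1 percentage points higher from compound 3 to compound 4 (beyond the scatter), because the single precedent a number 28.4 percentage points higher from compound 1 to compound 2 (beyond the scatter) is the only guide and a single precedent leaves room for a smaller or larger outcome. For compound 4 in this assay the estimate is 58%, with a range from 40% to 76%.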

Compound 4, a percentage reported as activity, at one concentration (the size of the read-out at that concentration, not a potency): 23.5%
Estimate against measurement, compound 4: 34.5 percentage points above, and the stated range ends above it.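

In this assay iodo in place of bromo gives a number 13.4 percentage points lower from compound 3 to compound 4 (beyond the scatter) and so does not carry over from the core of compound 1 in size or in direction: the same change on two cores in this assay, a number 28.4 percentage points higher (beyond the scatter) from compound 1 to compound 2 and a number 13.4 percentage points lower (beyond the scatter) from compound 3 to compound 4, 41.8 percentage points apart, beyond the scatter of two such steps. Read the other way, acetamidomethyl in place of nitro gives a number 40.1 percentage points lower from compound 2 to compound 4 (beyond the scatter) among the iodo compounds, a different outcome from the one among the bromo compounds: the same change on two cores in this assay, a number 1.7 percentage points higher (within the scatter) from compound 1 to compound 3 and a number 40.1 percentage points lower (beyond the scatter) from compound 2 to compound 4, 41.8 percentage points apart, beyond the scatter of two such steps. The core and the halogen therefore do not act independently in these four compounds, and a step measured on one core is no guide to the other; with one pair per core and a single tested concentration, the data do not show the reason for the reversal or which direction would prevail elsewhere in the series.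

As far as these compounds go, whether the reversal extends to chloro or methyl in place of the halogen on the phenyl ester remains open. Also open, from the compounds shown here alone, is how the halogen exchange behaves on a core carrying an amine or a carboxylic acid in place of nitro or acetamidomethyl.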